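A Second Benzylamino Group Replaces Fluorine on a Cytotoxic Core

The source may hold more compounds than are shown below. What is called first, only, known or untested is meant among the compounds shown, and "the series" means these compounds.

Compound 1 `N#Cc1c(NCc2ccccc2)c(Cl)c2nc(N)nc(N)c2c1F` is the strongest of three related compounds in a functional assay on HL-60 cells (Homo sapiens) for cytotoxicity, read by MTT assay (on this read-out lower numbers stand for stronger inhibition and higher numbers for weaker inhibition), where compound 1 gives 0.3 ug/mL. Two companions vary only the group attached to the amine nitrogen: compound 2 `CC(C)(C)Nc1c(C#N)c(F)c2c(N)nc(N)nc2c1Cl` gives 5.2 ug/mL, and compound 3 `CCN(CC)c1c(C#N)c(F)c2c(N)nc(N)nc2c1Cl` gives 2.3 ug/mL. Swapping the benzyl group for a tert-butyl group weakens the effect, as shown by a 17-fold higher number from compound 1 to compound 2 (1.24 log units; beyond the scatter); swapping benzylamino for diethylamino also weakens it, by a 7.7-fold higher number from compound 1 to compound 3 (0.88 log units; beyond the scatter); and between those two alternatives, a 2.3-fold lower number from compound 2 to compound 3 (0.35 log units; beyond the scatter) favours diethylamino. All three measured steps therefore test what hangs on that single amine, and none of them touches the fluorine.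

Compound 4 `N#Cc1c(NCc2ccccc2)c(Cl)c2nc(N)nc(N)c2c1NCc1ccccc1` makes a different change: benzylamino in place of fluoro on an aromatic carbon. Going by the values given here, no measured step bears on this move, so the expectation rests only on the observation that every alteration so far has nudged the number upward from compound 1, while the entering group is the same benzylamino that the most potent compound carries. A modest step upward, or none beyond the scatter, is therefore expected, a 2.7-fold higher number from compound 1 to compound 4 (0.43 log units; beyond the scatter). On that basis compound 4 is estimated at 0.8 ug/mL, within a range from 0.2 ug/mL to 4 ug/mL.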

Compound 4, half-maximal inhibitory concentration: 8.5 ug/mL
For compound 4 the middle estimate is 11-fold (1.03 log units) below the measured one, and the stated range ends below it.
By their numbers in this assay, from the lowest: compound 1; then compound 3; then compounds 2 and 4 (each within the scatter of the next).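

The carbon that carries the fluoro group in compound 1 proved sensitive to change in this assay: putting benzylamino there gives a 28-fold higher number from compound 1 to compound 4 (1.45 log units; beyond the scatter), a large step and the first one in this set made away from the original amine. The group that accompanies the lowest number at its first site therefore does not carry that advantage to this place, ortho to a cyano group and para to a chloro group, so the effect of a benzylamino group depends on where it stands on the core. The swap replaces a single fluorine with a group of 8 heavy atoms that brings an aromatic ring, a hydrogen-bond donor and a hydrogen-bond acceptor, and no supporting measurement is available to explain the loss of potency.

With all of these features entering together, the compounds shown cannot tell which of them accounts for the step. A small amino group or a methoxy group at this place, or a hydrogen in place of the fluorine, would show whether any replacement of fluoro raises the number or only a group as large as benzylamino does.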